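Ethyl to Isopropyl on a Shared Cyclic Urea Core

This account rests on a few compounds, and the source may have more. Where it says the series, first, only, none or still open, it means among the compounds named here.

Of the compounds shown here, three have been measured so far in an assay on RBL-1 cells for inhibition of Polyunsaturated fatty acid 5-lipoxygenase (Rattus norvegicus); on this read-out lower numbers stand for stronger inhibition and higher numbers for weaker inhibition. Among the measured compounds shown here, compound 1 `O=C1NCCN(c2cccc(F)c2)N1` gives 19000 nM, and compound 2 `O=C1NCCN(c2cccc(Cl)c2)N1` gives 5300 nM; the change a 3.6-fold lower number from compound 1 to compound 2 (0.55 log units; beyond the scatter) is the only single-site step among the measured pair. Compound 3 `CCC1CN(c2ccccc2)NC(=O)N1` gives 6900 nM, which is the second highest of the three numbers: its gap to compound 2 lies within the scatter, while compound 1 sits beyond the scatter above it.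

Compound 4 `CC(C)C1CN(c2ccccc2)NC(=O)N1` differs from compound 3 in one place: methyl in place of hydrogen on a saturated chain carbon bound to a saturated chain carbon and a saturated ring carbon. For the measured compounds named here, none of the measured steps bears on this change. Going by the values given here, the only measured step, from compound 1 to compound 2, concerns a halogen swap on an aromatic carbon and says nothing about enlarging the saturated chain on the core. Among the compounds with values here, with no comparable step available, the account expects no movement beyond the scatter in this assay from compound 3 to compound 4, that is no change at the digits printed from compound 3 to compound 4 (within the scatter) as the estimated step. Compound 4 is therefore estimated at 6900 nM in this assay, with a range from 2500 nM to 19000 nM that reflects the absence of any directly informative precedent.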

Compound 4, half-maximal inhibitory concentration: 6800 nM
Compound 4: middle estimate off by 1.0-fold (0.01 log units), on the high side; the range from low to high includes it.
By their numbers in this assay, from the lowest: compounds 2, 4 and 3 (each within the scatter of the next); then compound 1.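

In this assay, the swap of ethyl to isopropyl gives a 1.0-fold lower number from compound 3 to compound 4 (0.01 log units; within the scatter), so adding one methyl at this saturated chain carbon leaves the two compounds indistinguishable on this read-out. Among the compounds shown here, this is the first measured step at a saturated chain carbon on the shared core; the earlier step, a 3.6-fold lower number from compound 1 to compound 2 (0.55 log units; beyond the scatter), concerned only a halogen swap on an aromatic carbon and could not speak to this place. Nothing measured here bears on why the read-out holds level across this step.

The compounds shown leave open whether this place would accept groups of another kind as readily, such as a tert-butyl, a phenyl, an amine or a carboxylic acid, since ethyl and isopropyl are the only two groups compared there. They also leave open whether the step from fluoro to chloro seen on the aromatic carbon would read the same on a core carrying ethyl or isopropyl, as neither halogen appears together with those chains.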